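A few compounds are considered here, and "the series" means these few. Any claim that something is new, unique, unknown or untested is made for them only; others in the source may bear on it.

Working notes on the glucagon receptor series.

Of the compounds shown here, three of the shared core have been measured in an assay on cells for displacement of a labelled ligand from Glucagon receptor (Homo sapiens), in the presence of a further agent that is not named here; a lower number here means a stronger inhibitor, a higher number a weaker inhibitor. Compound 1 `CCCC(Oc1ccc(-n2cc3ccccc3n2)cc1)c1ccc(C(=O)NCCC(=O)O)cc1` gives 290 nM. Compound 2 `CCCC(Oc1ccc(-n2cc(C(F)(F)F)c(C)n2)cc1)c1ccc(C(=O)NCCC(=O)O)cc1` gives 1100 nM, and compound 3 `CCCC(Oc1ccc(-n2cc(C#N)cn2)cc1)c1ccc(C(=O)NCCC(=O)O)cc1` gives 4100 nM. Compound 3 therefore stands at the highest number of the three; the steps that reach it are a 14-fold higher number from compound 1 to compound 3 (1.15 log units; beyond the scatter) and a 3.7-fold higher number from compound 2 to compound 3 (0.57 log units; beyond the scatter), both beyond the scatter, and the remaining step is a 3.8-fold higher number from compound 1 to compound 2 (0.58 log units; beyond the scatter).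

Compound 4 `CCCC(Oc1ccc(-n2cc(Cl)cn2)cc1)c1ccc(C(=O)NCCC(=O)O)cc1` differs from compound 3 by chloro in place of cyano on an aromatic carbon. Among the compounds with values here, no measured step exchanges one single substituent on the five-membered ring for another while keeping the rest fixed; the nearest comparison is a 3.7-fold higher number from compound 2 to compound 3 (0.57 log units; beyond the scatter), in which the whole substitution pattern of that ring changes at once and the number moves by a modest amount. The two-ring replacements a 3.8-fold higher number from compound 1 to compound 2 (0.58 log units; beyond the scatter) and a 14-fold higher number from compound 1 to compound 3 (1.15 log units; beyond the scatter) bear on the change only loosely. Within the data shown here, with no direct precedent for chloro in place of cyano, the expectation for compound 4 is a step of a 1.6-fold lower number from compound 3 to compound 4 (0.21 log units; within the scatter) in this assay that need not leave the scatter, with a slight lean toward a lower number.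

Compound 4 is thus estimated at 2500 nM in this assay, with a range from 900 nM to 7000 nM.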

Compound 4, inhibition constant: 1100 nM
The estimate for compound 4 lay 2.3-fold (0.36 log units) above the measured number; the range from low to high includes it.
By their numbers in this assay, from the lowest: compound 1; then compounds 2 and 4 (each within the scatter of the next); then compound 3.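

In this assay, the exchange of chloro for cyano on an aromatic carbon, two ring bonds from the ring nitrogen, gives a step beyond the scatter (a 3.7-fold lower number from compound 3 to compound 4 (0.57 log units; beyond the scatter)), so this position responds to one small group while the rest of the molecule stays fixed. The single chloro also matches the fuller substitution of the 3-methyl-4-(trifluoromethyl)-1H-pyrazol-1-yl group (no change at the digits printed from compound 2 to compound 4 (within the scatter)), so the gap between compound 2 and compound 3 need not reflect the number of substituents on that ring, while 2H-indazol-2-yl keeps its lead over 4-chloro-1H-pyrazol-1-yl (a 3.8-fold higher number from compound 1 to compound 4 (0.58 log units; beyond the scatter)). No measurement offered here explains the difference between chloro and cyano at this position.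

The compounds shown do not tell how a bromo, a methyl or a methoxy group on the same carbon would compare with chloro and cyano. They also leave open whether an amine or a carboxylic acid is tolerated there, and whether the chloro result carries over to a chloro group on the indazole of compound 1.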